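From 3-methoxyphenyl to 4-methoxyphenyl in an antiproliferative series

The source may report more compounds than this note shows. Statements on the series, on what has been measured and on what is new or still open speak of the compounds shown alone.

Of the compounds shown here, three have been measured so far in a functional assay on A549 cells (Homo sapiens) for antiproliferative activity, read by MTT assay, with a stated time of 72 h (on this read-out higher numbers stand for weaker inhibition and lower numbers for stronger inhibition), and only one gave an actual number. Compound 1 `O=C1COc2ccc(-c3cnc(Cl)c(NS(=O)(=O)c4ccc(F)cc4)c3)cc2N1c1ccc(F)cc1` reads 22300 nM in this assay as its half-maximal inhibitory concentration. Compound 2 `COc1cccc(N2C(=O)COc3ccc(-c4cccc(NS(=O)(=O)c5ccc(F)cc5)c4)cc32)c1` reads > 40000 nM in this assay and this is a limit of the assay, not a number. Compound 3 `Cc1ccc(N2C(=O)COc3ccc(-c4cnc5ccccc5c4)cc32)cc1` reads > 40000 nM in this assay and this too is a limit. For the measured compounds named here, the picture thus rests largely on the limit of > 40000 nM in this assay, at which 2 of the 3 values shown sit, and offers no measured step between compounds, so compound 2 has no exact position on the scale.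

Compound 4 `COc1ccc(N2C(=O)COc3ccc(-c4cccc(NS(=O)(=O)c5ccc(F)cc5)c4)cc32)cc1` is the next to be read. The change 4-methoxyphenyl in place of 3-methoxyphenyl on an amide-type nitrogen in a ring puts 4-methoxyphenyl in place of 3-methoxyphenyl on an amide-type nitrogen in a ring, and the two compounds have the same atoms, joined differently. No shift beyond the usual scatter is expected in this assay and no direction can be favoured. That expectation rests on compound 2 at > 40000 nM as a limit of the assay. The expected size of an at least 1.0-fold lower number from compound 2 to compound 4 (0.02 log units; that floor lies within the scatter) is therefore small. For compound 4 the estimate is 38000 nM in this assay with an expected range from 15000 nM to 70000 nM on the same read-out.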

Compound 4, half-maximal inhibitory concentration: 38200 nM
Compound 4: middle estimate off by 1.0-fold (0.00 log units), on the low side; the range from low to high includes it.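

For the compounds shown here, this pair gives the first step that can be read at this position, on an amide-type nitrogen in a ring. In this assay, 4-methoxyphenyl in place of 3-methoxyphenyl gives an at least 1.0-fold lower number from compound 2 to compound 4 (0.01 log units; that floor lies within the scatter), so the change shows no shift beyond the scatter, and it does not establish that either group is better than the other. As far as these compounds go, compound 4 does give a measured value where compound 2 has only a limit of the assay, but the true size of the step stays unknown because one end of it is that limit: the limit of > 40000 nM in this assay, at which 2 of the 4 values shown sit.

Compound 1 and compound 3 differ from compound 4 in more than one place, so neither can show what this position contributes on its own, and the steps to them cannot be read. From the compounds shown here alone, whether an amine or a carboxylic acid on this phenyl ring, in place of the methoxy group, would give a number clearly lower than that of compound 4 remains open, as does the question of whether any group at this position moves the value beyond the scatter.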